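The source may report more compounds than this note shows. Statements on the series, on what has been measured and on what is new or still open speak of the compounds shown alone.

Compound 1 `CC(C)(C)c1cc2c(Oc3ccccc3F)ncnc2s1`: < 5% (a limit of the assay)
Compound 2 `CC(C)(C)c1sc2ncnc(Oc3ccccc3F)c2c1-c1ccccc1`: 14%

Going by the values given here, in an ADME assay on microsomes from liver (Mus musculus) for metabolic stability, read by LC-MS, using NADPH, with a stated time of 30 min (a higher number here means that more of the compound is left, a lower number that less of the compound is left), compound 2 gives 14%, the only actual number so far. Compound 1 gives < 5%, which is a limit of the assay.

Compound 3 `CC(C)(C)c1sc2ncnc(Oc3ccccc3F)c2c1-c1ccc(F)cc1` differs from compound 2 by fluoro in place of hydrogen on an aromatic carbon, para to a large group, phenyl to 4-fluorophenyl (fluoro in place of hydrogen on an aromatic carbon). Among the compounds with values here, the only measured step, a number at least 9 percentage points higher from compound 1 to compound 2 (that floor lies within the scatter), concerns a different change, so no step beyond the scatter is expected in this assay, and no direction is favoured. The expected step is a number 2 percentage points higher from compound 2 to compound 3 (within the scatter). Compound 3 is estimated at 16%, with an expected range from 6% to 35%.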

Compound 3, percent of the compound remaining: 7%
Compound 3: the middle estimate sits 9 percentage points above what was measured; the range from low to high includes it.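

In this assay, fluoro in place of hydrogen on the phenyl ring, para to a large group, gives a number 7 percentage points lower from compound 2 to compound 3 (within the scatter), so this position shows no effect of the change that stands clear of the scatter. The 4-fluorophenyl group in place of hydrogen on the core gives a number at least 2 percentage points higher from compound 1 to compound 3 (that floor lies within the scatter). That step is only a floor, as compound 1 holds a limit and not a number: the limit of < 5% in this assay, at which 1 of the 3 values shown sits.

Going by these compounds, whether an amine or a carboxylic acid at this same place on the ring would stand clear of compound 2 remains open. So does the effect of a methoxy group there.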